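From Carboxylic Acid to Propargyl Amide on One Core

This account rests on a few compounds, and the source may have more. Where it says the series, first, only, none or still open, it means among the compounds named here.

Measured so far:
compound 1 `COc1ccc2c(c1)cc(C(=O)NCc1ccccc1)n2C`, > 100000 nM
compound 2 `Cn1c(C(=O)O)cc2cc(OCCCC3CCN(Cc4ccccc4)CC3)ccc21`, > 100000 nM
compound 3 `Cn1c(C(=O)N2CCOCC2)cc2cc(OCCCC3CCN(Cc4ccccc4)CC3)ccc21`, > 100000 nM

All three compounds were tested in an assay on isolated protein for inhibition of Amine oxidase [flavin-containing] A (Homo sapiens), read by fluorescence, with stated times of 30 min and 1 h; a higher number here means a weaker inhibitor, a lower number a stronger inhibitor. Compound 1 gives only a limit of the assay, > 100000 nM, not a number. Compound 2 likewise gives only a limit, > 100000 nM. Compound 3 also gives only a limit, > 100000 nM. So compound 2 stands at the edge of what the assay can report, and nothing shown places it above or below either of the others.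

Within the data shown here, the one step among measured compounds that changes a single place is a step that the two limits leave unreadable from compound 2 to compound 3, and because both ends sit at the limit described by the limit of > 100000 nM in this assay, at which 3 of the 3 values shown sit, its size cannot be read.

Compound 4 is `C#CCNC(=O)c1cc2cc(OCCCC3CCN(Cc4ccccc4)CC3)ccc2n1C`. It differs from compound 2 by propargylamino in place of hydroxy on a carbonyl carbon. Among the measured compounds shown here, no measured step covers this change; the only related step, from the acid to the morpholine amide, is unreadable, so no direction can be taken from it.

The expectation for compound 4 in this assay therefore rests only on three limits, and it is estimated at 30000 nM, within 300 nM to 100000 nM, which corresponds to an expected step of an at least 3.3-fold lower number from compound 2 to compound 4 (0.52 log units; beyond the scatter).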

Compound 4, half-maximal inhibitory concentration: > 100000 nM
Compound 4: no number, only a limit; the forecaster's own chance of this, stated with the estimate: 55%; at least 3.3-fold (0.52 log units) between middle value and limit.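

In this assay compound 4 gives only a limit, > 100000 nM. No new step can be read from compound 2 or compound 3 to compound 4, because all of these results share one boundary: the limit of > 100000 nM in this assay, at which 4 of the 4 values shown sit. The compounds shown leave open how strongly any of them inhibits this protein, and whether changing the group on the carbonyl carbon affects that inhibition.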